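Methyl to Methoxy: Expected Cytotoxicity of Compound 4

The source may report more compounds than this note shows. Statements on the series, on what has been measured and on what is new or still open speak of the compounds shown alone.

Of the compounds shown here, three sharing one core have been tested in a functional assay on HSC-4 cells (Homo sapiens) for cytotoxicity, with a stated time of 24 h; on this read-out lower numbers stand for higher toxicity in this test and higher numbers for lower toxicity in this test. Compound 1 `Cc1ccc(/C=C2\CCC/C(=C\c3ccccc3[N+](=O)[O-])C2=O)cc1` gives 40000 nM in this assay. Compound 2 `COc1ccc(/C=C2\CCC/C(=C\c3ccccc3[N+](=O)[O-])C2=O)cc1` gives 24000 nM in this assay. Compound 3 `Cc1ccc(/C=C2\CCC/C(=C\c3cccc([N+](=O)[O-])c3)C2=O)cc1` gives 45000 nM in this assay. All three numbers lie within the usual scatter of one another, so none of the three can be set apart from the others.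

Compound 2 differs from compound 1 by methoxy in place of methyl on an aromatic carbon. That change produced a 1.7-fold lower number from compound 1 to compound 2 (0.22 log units; within the scatter). Compound 3 is built from the same atoms as compound 1, joined differently; the difference between the two cores is not broken down here.

Compound 4 `COc1ccc(/C=C2\CCC/C(=C\c3cccc([N+](=O)[O-])c3)C2=O)cc1` has not yet been measured. It differs from compound 3 by methoxy in place of methyl on an aromatic carbon, and this is the same change, at the same place, that turns compound 1 into compound 2. A step of about the same size is expected, a 1.7-fold lower number from compound 3 to compound 4 (0.22 log units; within the scatter), because the earlier instance gave a 1.7-fold lower number from compound 1 to compound 2 (0.22 log units; within the scatter), although a single earlier example makes the expectation loose. In this assay compound 4 is expected to give 27000 nM, with a range from 13000 nM to 55000 nM.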

Compound 4, half-maximal cytotoxic concentration: 11000 nM
Compound 4: middle estimate off by 2.5-fold (0.39 log units), on the high side; the measured number lies below the stated range.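

In this assay, replacing methyl with methoxy, the change from 4-methylphenyl to 4-methoxyphenyl, gave a 4.1-fold lower number from compound 3 to compound 4 (0.61 log units; beyond the scatter), whereas the same change on the core of compound 1 stayed within the usual scatter. Set side by side, the two steps cannot be told apart in size: the same change on two cores in this assay, a 1.7-fold lower number (0.22 log units; within the scatter) from compound 1 to compound 2 and a 4.1-fold lower number (0.61 log units; beyond the scatter) from compound 3 to compound 4, 2.5-fold (0.39 log units) apart, within the scatter of two such steps. This means the change can be carried between these two cores with no detectable difference in its effect, but two pairs of compounds cannot show that the step has a fixed size or that it would hold on a third core.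

The compounds shown leave open whether other groups on the same aromatic carbon, such as a hydroxyl, an ethoxy or an amine, would give a step like that of methoxy. They also leave open whether the methyl-to-methoxy step would persist if the nitro group on the other aromatic ring were replaced by a nitrile or a carboxylic acid.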